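The source may report more compounds than this note shows. Statements on the series, on what has been measured and on what is new or still open speak of the compounds shown alone.

Values in a functional assay on HCT-116 cells (Homo sapiens) for antiproliferative activity, read by MTT assay, with a stated time of 48 h; a higher number here means a weaker inhibitor, a lower number a stronger inhibitor:

compound 1 `Cc1ccc2nc(Nc3ccnc(Nc4ccc(S(C)(=O)=O)cc4)n3)sc2c1`: 1750 nM
compound 2 `Cc1cnc(Nc2ccc([N+](=O)[O-])cc2)nc1Nc1nc2ccccc2s1`: 6330 nM
compound 3 `CS(=O)(=O)c1ccc(Nc2nccc(Nc3nc4ccc(F)cc4s3)n2)cc1`: 860 nM

Compound 2 stands highest of the three numbers; compound 1 lies nearest and compound 3 furthest below it. Among the compounds with values here, the only measured step is a 2.0-fold lower number from compound 1 to compound 3 (0.31 log units; beyond the scatter), a change on the fused ring that does not touch the aryl group varied here. Compound 4 `Cc1cnc(Nc2ccc(C(C)C)cc2)nc1Nc1nc2ccccc2s1` differs from compound 2 by isopropyl in place of nitro on an aromatic carbon. Within the data shown here, no measured pair shows this exchange, so the expectation rests on the size of the one step seen: a change of modest size, direction uncertain. The step expected is a 1.3-fold lower number from compound 2 to compound 4 (0.10 log units; within the scatter). Compound 4 is therefore estimated at 5000 nM, within 1500 nM to 15000 nM.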

Compound 4, half-maximal inhibitory concentration: > 50000 nM
Compound 4 ended at the assay's limit (the forecaster's own chance of this, stated with the estimate: 5%); middle value at least 10-fold (1.00 log units) from the limit.
By their numbers in this assay, from the lowest: compound 3; then compound 1; then compound 2. At a limit, above all of these: compound 4.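

Within the data shown here, the step at this position is large: exchanging 4-nitrophenyl for 4-isopropylphenyl on the core of compound 2 gives in this assay an at least 7.8-fold higher number from compound 2 to compound 4 (0.89 log units; beyond the scatter), whereas the one earlier step, made on the fused ring, was modest. Compound 4 stands at a limit of the assay, so the size of the step has a floor but no measured end: the limit of > 50000 nM in this assay, at which 1 of the 4 values shown sits. Isopropyl on this aromatic carbon is therefore not an interchangeable replacement for nitro.

Among these compounds, what separates the two groups stays open, since only this one exchange is read here. An amine, a nitrile or a carboxylic acid at the same place would show whether the series follows hydrogen-bond acceptors or something else.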